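This account rests on a few compounds, and the source may have more. Where it says the series, first, only, none or still open, it means among the compounds named here.

Values measured in a physicochemical assay for solubility, read by HPLC, using the shake flask method, measured as kinetic solubility, with a stated time of 20 h, at pH 6.5, tested at 200 uM (on this read-out higher numbers stand for higher solubility and lower numbers for lower solubility), are as follows
- compound 1 (`C[C@@H](CO)NS(=O)(=O)c1cccc(-c2ccc3nccc(-c4ccncc4)c3n2)c1`) gives 50000 nM
- compound 2 (`CS(=O)(=O)c1cccc(-c2ccc3nccc(N4CCNCC4)c3n2)c1`) gives 165000 nM
- compound 3 (`c1cc(-c2ccnc3ccc(NC4CC4)nc23)ccn1`) gives 90000 nM

Compound 1 at 50000 nM and compound 3 at 90000 nM lie within the scatter of each other. Compound 2 gives 165000 nM and stands beyond the scatter on the high side of compound 1, the furthest gap among these three numbers.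

The next compound to be read is compound 4 (`O=S(=O)(CCO)c1cccc(-c2ccc3nccc(-c4ccncc4)c3n2)c1`). It keeps the core of compound 1 and carries 2-hydroxyethyl in place of (1-(hydroxymethyl)ethyl)amino on a sulfonyl sulfur.

Going by the values given here, no two measured compounds differ in one place, so the series offers no measured step for this change, and its direction in this assay stays open. Among the compounds with values here, the only close reference is compound 1 at 50000 nM and the expectation therefore stays near that number. The estimated change is no change at the digits printed from compound 1 to compound 4 (within the scatter) and is not expected to go beyond the scatter. For compound 4 the expected value is 50000 nM with 16000 nM to 150000 nM as the estimated range.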

Compound 4, solubility: 55000 nM
Beside the measured number, compound 4's estimate is 1.1-fold (0.04 log units) below it, within the range that was stated.
By their numbers in this assay, from the lowest: compounds 1, 4, 3 and 2 (each within the scatter of the next, the first and the last beyond it).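

In this assay, going by these compounds alone, 2-hydroxyethyl in place of (1-(hydroxymethyl)ethyl)amino on a sulfonyl sulfur gives a 1.1-fold higher number from compound 1 to compound 4 (0.04 log units; within the scatter), the first step that can be read at a single place. With the core of compound 1 held constant, the amino nitrogen and the defined stereocentre both leave in this change, yet the read-out stays within the scatter, so neither feature is needed at this place to hold the number at this level on this core. No measurement available here explains this outcome.

Compounds 2 and 3 differ from compound 1 and compound 4 in more than one place, so steps to them cannot be read, and the gap between compound 1 and compound 2 cannot be assigned to any one part of the structure. As far as these compounds go, with a single change at the sulfonyl sulfur, it remains open whether a longer chain, a carboxylic acid or a piperazine at that place would stay within the scatter or move the number beyond it.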